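A few compounds are considered here, and "the series" means these few. Any claim that something is new, unique, unknown or untested is made for them only; others in the source may bear on it.

In a functional assay on the whole organism (strain Sprague-Dawley) for inhibition, with Rattus norvegicus as the target, with a stated time of 10 min (on this read-out higher numbers stand for an effect only at larger amounts of compound and lower numbers for an effect already at smaller amounts), three compounds have been measured so far:

compound 1 `CCOC(=O)c1cnc(-c2ccccc2OCC)[nH]c1=O`: 2 mg/kg
compound 2 `CCOC(=O)c1cnc(-c2ccccc2OCC(C)C)[nH]c1=O`: 3 mg/kg
compound 3 `CCOC(=O)c1cnc(-c2ccccc2OC(C)CC)[nH]c1=O`: 0.5 mg/kg

Compound 3 has the lowest number of the three, and its gaps to both others lie beyond the scatter. The next compound, compound 4 `CCOC(=O)c1cnc(-c2ccccc2SCC)[nH]c1=O`, has ethylsulfanyl in place of sec-butoxy on an aromatic carbon.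

For the measured compounds named here, three measured steps bear on this change. The first, a 1.5-fold higher number from compound 1 to compound 2 (0.18 log units; within the scatter), does not separate those two compounds. The other two, a 4.0-fold lower number from compound 1 to compound 3 (0.60 log units; beyond the scatter) and a 6.0-fold lower number from compound 2 to compound 3 (0.78 log units; beyond the scatter), are modest but real, and both end at the sec-butoxy compound. Removing that chain might therefore give back a step of similar size, towards a higher number in this assay. Going by the values given here, no measured step exchanges oxygen for sulfur, so that part of the change has no direct precedent and the range must stay wide. The nearest measured side chain belongs to compound 1, which carries an ethyl chain on oxygen and gives 2 mg/kg. The expected change is modest and upward, estimated as a 5.0-fold higher number from compound 3 to compound 4 (0.70 log units; beyond the scatter). For compound 4 the estimated value is 2.5 mg/kg, with an expected range from 0.7 mg/kg to 9 mg/kg.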

Compound 4, dose for 50% inhibition: > 5 mg/kg
Compound 4: only a limit was reported; the forecaster's own chance of this, stated with the estimate: 5%; middle value at least 2.0-fold (0.30 log units) from the limit.
By their numbers in this assay, from the lowest: compound 3; then compounds 1 and 2 (each within the scatter of the next). At a limit, above all of these: compound 4.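

In this assay compound 4 is reported only as a limit, not as a number: the limit of > 5 mg/kg in this assay, at which 1 of the 4 values shown sits. The closest comparison is ethylsulfanyl in place of ethoxy, where the ethyl chain stays and only the atom linking it to the aromatic carbon changes, and it gives an at least 2.5-fold higher number from compound 1 to compound 4 (0.39 log units; beyond the scatter); so the earlier finding, that the oxygen-linked chains differ among themselves, now gains a first sign that the linking atom matters as well, and the exchange against sec-butoxy gives the largest step in the set, an at least 10-fold higher number from compound 3 to compound 4 (1.00 log units; beyond the scatter). Against isobutoxy the change gives an at least 1.6-fold higher number from compound 2 to compound 4 (0.22 log units; that floor lies within the scatter), so that comparison alone does not separate the two compounds, and the sign for the linking atom rests on the other two steps.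

From the compounds shown here alone, how far compound 4 lies beyond its limit remains unknown, so all three steps are floors and not sizes. Going by these compounds, it also remains open whether a sec-butylsulfanyl chain would bring back the low number seen with sec-butoxy, and whether an ethylamino group at this aromatic carbon would follow the ethoxy or the ethylsulfanyl compound.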